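The compounds below may be only part of what the source reports. "The series", "measured", "known", "first", "only" and "open" are said of these compounds alone.

Measured compounds:

Compound 1, `CNc1nc(Nc2ccc(C)c(N)c2)ncc1C(=O)Nc1cc(NC(=O)c2cccc(C(F)(F)F)c2)ccc1C`, in an ADME assay on BaF3 cells (Mus musculus) for antiproliferative activity, read by CellTiter-Glo and CCK-8 assay, with a stated time of 72 h (a higher number here means a weaker inhibitor of growth, a lower number a stronger inhibitor of growth), gives > 10000 nM.
Compound 2, `CNc1nc(Nc2ccc(C)c([N+](=O)[O-])c2)ncc1C(=O)Nc1cc(NC(=O)c2ccc(OC)cc2)ccc1C`, in this assay gives > 10000 nM.
Compound 3, `CNc1nc(Nc2ccc(C)c(N)c2)ncc1C(=O)Nc1cc(NC(=O)c2cccc(OC)c2)ccc1C`, in this assay gives > 10000 nM.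

Each of these three values is a limit of the assay and not a number: the growth inhibition was too weak to be measured within the tested range. Compound 3 therefore stands at the same limit as the other two, and nothing finer can be said about where it lies. For the measured compounds named here, the one step between measured compounds that differ in a single place, a step that the two limits leave unreadable from compound 1 to compound 3, cannot be read either, since both ends sit at the limit of > 10000 nM in this assay, at which 3 of the 3 values shown sit.

Compound 4, `CNc1nc(Nc2ccc(C)c(N)c2)ncc1C(=O)Nc1cc(NC(=O)c2ccc(OC)cc2)ccc1C`, is the remaining isomer: 4-methoxyphenyl in place of 3-methoxyphenyl on a carbonyl carbon. Going by the values given here, no measured step bears on this change directly. Compound 2 carries the same 4-methoxyphenyl group on a different left-hand part and also gives only a limit, so no sign of gained growth inhibition appears anywhere in the set. The step that the limit leaves unreadable from compound 3 to compound 4 is expected to be none beyond the scatter, and compound 4 is expected to give about 15000 nM, within 5000 nM to 50000 nM, most likely again reported only as a limit.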

Compound 4, concentration for 50% growth inhibition: > 10000 nM
Compound 4 was reported as a limit; the forecaster's own chance of this, stated with the estimate: 85%; the middle value does not contradict the limit.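

The steps linking compound 4 to compound 1, compound 2 and compound 3 cannot be read, because each ends at a limit of the assay and not at a number: the limit of > 10000 nM in this assay, at which 4 of the 4 values shown sit.

The compounds shown leave open how far apart they truly lie, and which change to the shared core would give measurable growth inhibition in this assay.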